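The source may report more compounds than this note shows. Statements on the series, on what has been measured and on what is new or still open speak of the compounds shown alone.

Measured compounds:
- Compound 1, `CCOC(=O)c1oc2nc(-c3cccs3)cc(C(F)(F)F)c2c1N`: in an ADME assay on Huh-7 cells (Homo sapiens) for cytotoxicity, read by MTT assay, with a stated time of 72 h (on this read-out higher numbers stand for lower toxicity in this test and lower numbers for higher toxicity in this test), compound 1 gives > 20000 nM, which is a limit of the assay and not a number.
- Compound 2, `CN(C)C(=O)c1sc2nc(-c3ccccc3)cc(C(F)(F)F)c2c1N`: in this assay compound 2 gives > 20000 nM, again a limit of the assay rather than a measured number.

Compound 2 thus stands at the edge of what this test reports, and the two values shown do not separate the two compounds, since both sit at the limit of > 20000 nM in this assay, at which 2 of the 2 values shown sit. For the measured compounds named here, no step between compounds that differ in one place has been measured, so nothing is known about how large a change in the amide group moves the read-out. The unmeasured compound 3, `Nc1c(C(=O)NCc2cccs2)sc2nc(-c3ccccc3)cc(C(F)(F)F)c12`, differs from compound 2 by ((thiophen-2-yl)methyl)amino in place of dimethylamino on a carbonyl carbon. Given (the limit of > 20000 nM in this assay, at which 2 of the 2 values shown sit), the step expected is a step that the limit leaves unreadable from compound 2 to compound 3, that is, no change beyond the usual scatter. Compound 3 is therefore estimated at 30000 nM in this assay, with a range from 10000 nM to 100000 nM, and most likely again reported only as a limit.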

Compound 3, half-maximal cytotoxic concentration: > 20000 nM
Compound 3 was reported as a limit; the forecaster's own chance of this, stated with the estimate: 70%; the middle value lies beyond the limit too.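

The step from compound 2 to compound 3 cannot be read, since neither compound gives a number in this assay: the limit of > 20000 nM in this assay, at which 3 of the 3 values shown sit.

The compounds shown leave open which change to the amide group or the shared core, if any, would give a measurable value in this assay.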